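The compounds below may be only part of what the source reports. "The series", "measured", "known", "first", "only" and "open" are said of these compounds alone.

Measured so far in a functional assay on the whole organism (Pleural cavity) for inhibition, with Rattus norvegicus as the target, at a dose of 25 mg/kg; a lower number here means less inhibition, a higher number more inhibition at the dose given (going by the name of the read-out):
- compound 1 `CC1(Sc2ccccc2)C(=O)N(c2ccccc2)c2ncccc21`: 0%
- compound 2 `CC1(C)C(=O)N(c2ccccc2Cl)c2ncccc21`: 3%
- compound 3 `CC1(C)C(=O)N(Cc2ccccc2)c2ncccc21`: 12%

Compound 1 stands lowest of these three numbers. Its nearest neighbour is compound 2, whose value lies within the usual scatter of compound 1, so no order between the two can be read. Compound 3 lies beyond the scatter above compound 1, and that is the only gap here that counts as a real difference. Among the compounds with values here, none of the three measured compounds differs from another in a single place, so no single step has been isolated within the measured set.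

Compound 4 `COCCSC1(C)C(=O)N(c2ccccc2)c2ncccc21` is not yet measured. It differs from compound 1 in one place: 2-methoxyethyl in place of phenyl on a sulfur. Within the data shown here, there is no measured pair that shows what exchanging a phenyl for a 2-methoxyethyl on that sulfur does in this assay, and all three measured values sit low. The expectation for the step from compound 1 to compound 4 is therefore small, a number 5 percentage points higher from compound 1 to compound 4 (within the scatter), and not beyond the scatter in either direction. For compound 4 the estimate is 5%, with a range from -5% to 20%.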

Compound 4, a percentage reported as inhibition, in the whole organism at one dose (the size of the read-out at that dose, not a potency): 23%
Compound 4: middle estimate off by 18 percentage points, on the low side; the whole stated range lies below it.
By their numbers in this assay, from the lowest: compounds 1, 2 and 3 (each within the scatter of the next, the first and the last beyond it); then compound 4.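

In this assay, within the data shown here, exchanging phenyl for 2-methoxyethyl on a sulfur gives a number 23 percentage points higher from compound 1 to compound 4 (beyond the scatter), so the group on this sulfur can change the read-out, which the earlier compounds could not show because no two of them differed in a single place. The change replaces an aromatic ring with an open chain carrying one hydrogen-bond acceptor, and compound 4 reaches 23% at the dose given. Nothing available explains why this exchange raises the number.

The compounds shown do not separate the loss of the phenyl ring from the arrival of the oxygen, a question that a plain butyl chain on the sulfur would address. They also leave open how an amine or a carboxylic acid at the end of the chain, or a longer chain, would read in this assay.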